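A few compounds are considered here, and "the series" means these few. Any claim that something is new, unique, unknown or untested is made for them only; others in the source may bear on it.

In a physicochemical assay for solubility (on this read-out lower numbers stand for lower solubility and higher numbers for higher solubility), compound 1 (`O=C(c1ccccc1)N1CCC(NS(=O)(=O)c2cc(S(=O)(=O)c3ccccc3)ccc2C(F)(F)F)CC1`) gives 12500 nM, compound 2 (`O=C(c1ccc(Cl)cc1)N1CCC(NS(=O)(=O)c2cc(S(=O)(=O)c3ccccc3)ccc2C(F)(F)F)CC1`) gives 3100 nM and compound 3 (`O=C(c1ccc(C(F)(F)F)cc1)N1CCC(NS(=O)(=O)c2cc(S(=O)(=O)c3ccccc3)ccc2C(F)(F)F)CC1`) gives 6300 nM. Compound 3 thus lies within the scatter of compound 1 and just beyond it from compound 2. Compound 4 (`CN(C)c1ccc(C(=O)N2CCC(NS(=O)(=O)c3cc(S(=O)(=O)c4ccccc4)ccc3C(F)(F)F)CC2)cc1`) carries dimethylamino in place of trifluoromethyl on an aromatic carbon, para to a large group: dimethylamino in place of trifluoromethyl on an aromatic carbon. The measured changes at this place are modest: a 4.0-fold lower number from compound 1 to compound 2 (0.61 log units; beyond the scatter), a 2.0-fold lower number from compound 1 to compound 3 (0.30 log units; within the scatter) and a 2.0-fold higher number from compound 2 to compound 3 (0.31 log units; beyond the scatter). For the measured compounds named here, none of the measured compounds carries dimethylamino, so no step beyond the scatter is expected in this assay. The expected step is a 1.3-fold lower number from compound 3 to compound 4 (0.10 log units; within the scatter). For compound 4 the estimated value is 5000 nM, with an expected range from 1800 nM to 14000 nM.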

Compound 4, solubility: 50000 nM
The estimate for compound 4 lay 10-fold (1.00 log units) below the measured number; measured number above the stated range.
By their numbers in this assay, from the lowest: compound 2; then compounds 3 and 1 (each within the scatter of the next); then compound 4.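

In this assay, for the compounds shown here, dimethylamino is the only group at this place that raises the number relative to the hydrogen of compound 1 (a 4.0-fold higher number from compound 1 to compound 4 (0.60 log units; beyond the scatter)). The steps from the other two substituents are larger still (a 7.9-fold higher number from compound 3 to compound 4 (0.90 log units; beyond the scatter); a 16-fold higher number from compound 2 to compound 4 (1.21 log units; beyond the scatter)), so the group on this aromatic carbon can move the number in either direction. Nothing available here explains the rise. The compounds shown leave open whether a primary amine or a morpholine at this place would give a similar rise, and whether a carboxylic acid would.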